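The source may report more compounds than this note shows. Statements on the series, on what has been measured and on what is new or still open speak of the compounds shown alone.

Measured compounds:

Compound 1 `CCCC(=O)Nc1cccc(Oc2cccc(OC)c2)c1` – in an assay on isolated protein for binding affinity to melatonin receptor type 1A (Homo sapiens) (on this read-out higher numbers stand for weaker inhibition and lower numbers for stronger inhibition), compound 1 gives > 500 nM, which is a limit of the assay and not a number.
Compound 2 `CCC(=O)Nc1ccc(Oc2cccc(OC)c2)cc1` – in this assay compound 2 gives 300 nM.

For the measured compounds named here, compound 2 is the only compound of the two with an actual number; the other value is a limit, (the limit of > 500 nM in this assay, at which 1 of the 2 values shown sits). Compound 3 `CCNC(=O)Nc1ccc(Oc2cccc(OC)c2)cc1` has not yet been measured in this assay. It differs from compound 2 in one place: ethylamino in place of ethyl on a carbonyl carbon, so the amide in compound 2 becomes a urea in compound 3. Going by the values given here, no measured pair shows what such a change does here, so any expectation rests on compound 2 alone. The expectation is for a step of modest size toward weaker binding, from compound 2 to compound 3 of about a 2.7-fold higher number from compound 2 to compound 3 (0.43 log units; beyond the scatter), and with that a fair chance that only a limit is reported. The estimate for compound 3 in this assay is therefore 800 nM, within a range from 200 nM to 3000 nM.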

Compound 3, inhibition constant: > 500 nM
Compound 3 was reported as a limit; the forecaster's own chance of this, stated with the estimate: 40%; the middle value is on the limit's open side.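

For the compounds shown here, replacing ethyl with ethylamino on a carbonyl carbon, which turns the amide into a urea, is the first change in one place that can be read in this assay, and it gives an at least 1.6-fold higher number from compound 2 to compound 3 (0.22 log units; that floor lies within the scatter). The value of compound 3, > 500 nM, is a limit of the assay and not a number. The change therefore brings no stronger binding, but with only a floor for the step, the data do not establish a real weakening.

How far the number for compound 3 lies past the limit cannot be read, and only one compound shown has an actual number: the limit of > 500 nM in this assay, at which 2 of the 3 values shown sit. Also open, as far as these compounds go, is what a methylamino group or a longer chain such as propylamino would do on the same carbonyl carbon.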